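Hydroxy-acyl prolinamide series: benzyl for methoxy-methylethyl

The source may hold more compounds than are shown below. What is called first, only, known or untested is meant among the compounds shown, and "the series" means these compounds.

Measured so far:
compound 1, `CC1(C[C@@H](O)C(=O)N2[C@@H]3C[C@@H]3C[C@H]2C(=O)NCc2cc(Cl)ccc2-n2cnnn2)CC1`, 1300 nM
compound 2, `O=C(NCc1cc(Cl)ccc1-n1cnnn1)[C@@H]1CC=NN1C(=O)[C@H](O)Cc1ccccc1`, 1400 nM
compound 3, `COC(C)(C)[C@@H](O)C(=O)N1C[C@H]2C[C@H]2[C@H]1C(=O)NCc1cc(Cl)ccc1-n1cnnn1`, 1000 nM

All three were run in a functional assay on a cell-free system (plasma, Homo sapiens), with a stated time of 3 min; on this read-out higher numbers stand for weaker inhibition and lower numbers for stronger inhibition. Compound 3 gives 1000 nM, the lowest of the three numbers, but its gaps to compound 1 and to compound 2 both fall within the usual scatter, so no order among the three can be claimed. For the measured compounds named here, no pair of measured compounds differs in one place, and thus no step between measured compounds is available.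

Compound 4, `O=C(NCc1cc(Cl)ccc1-n1cnnn1)[C@@H]1[C@@H]2C[C@@H]2CN1C(=O)[C@H](O)Cc1ccccc1`, has not yet been measured in this assay. It differs from compound 3 in one place:

benzyl in place of 1-methoxy-1-methylethyl on a saturated chain carbon bound to a carbonyl carbon and an oxygen on a saturated carbon

Compound 2 carries the same benzyl on a different core, and compound 2 gives 1400 nM, close to the value of compound 3. No step size beyond the scatter is therefore expected from compound 3 to compound 4; the estimated step is a 1.3-fold higher number from compound 3 to compound 4 (0.11 log units; within the scatter). Compound 4 is accordingly expected to give about 1300 nM in this assay, with a range from 600 nM to 2800 nM.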

Compound 4, half-maximal inhibitory concentration: 970 nM
Compound 4: middle estimate off by 1.3-fold (0.13 log units), on the high side; low and high end bracket the measured number.
By their numbers in this assay, from the lowest: compounds 4, 3, 1 and 2 (each within the scatter of the next).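

In this assay, benzyl in place of 1-methoxy-1-methylethyl on a saturated chain carbon bound to a carbonyl carbon and an oxygen on a saturated carbon gives a 1.0-fold lower number from compound 3 to compound 4 (0.01 log units; within the scatter) and so leaves the read-out within the scatter. For the compounds shown here, this is the first comparison that changes this position alone on an unchanged core, and it sets a group with no ring and one hydrogen-bond acceptor level with a group carrying a six-membered aromatic ring of carbon only and no hydrogen-bond acceptor. Nothing available bears on why the two groups read alike.

From the compounds shown here alone, it stays open whether the same holds on the cores of compound 1 and compound 2, as neither compound has a partner here that differs from it in one place. Also open, going by these compounds, is how this position responds to a group of another kind, such as an amine, a carboxylic acid or a longer chain, and whether any such group moves the number beyond the scatter.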